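The source may hold more compounds than are shown below. What is called first, only, known or untested is meant among the compounds shown, and "the series" means these compounds.

In a functional assay on KBVIN cells (Homo sapiens) for antiproliferative activity, read by sulforhodamine B assay, with a stated time of 3 days (on this read-out higher numbers stand for an effect only at larger amounts of compound and lower numbers for an effect already at smaller amounts), three compounds built on a shared core have been measured. Compound 1 `CCC1=C(O)c2c(oc(-c3ccc(C(F)(F)F)cc3)cc2=O)C(CC)(CC)C1=O`, bearing trifluoromethyl, gives 10.4 uM. Among the compounds with values here, compound 2 `CCCOc1ccc(-c2cc(=O)c3c(o2)C(CC)(CC)C(=O)C(CC)=C3O)cc1`, bearing propoxy, gives 29.2 uM, and the modest 2.8-fold higher number from compound 1 to compound 2 (0.45 log units; beyond the scatter) is the only measured step beyond the scatter. Compound 3 `CCC1=C(O)c2c(oc(-c3ccc(Br)cc3)cc2=O)C(CC)(CC)C1=O`, bearing bromo, gives 15.7 uM, which stands within the scatter of both other values.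

The next change leads to compound 4 `CCC1=C(O)c2c(oc(-c3ccc(F)cc3)cc2=O)C(CC)(CC)C1=O`, with fluoro in place of bromo on an aromatic carbon. Within the data shown here, no fluoro compound has been measured, so the only guidance comes from the two steps that bring in bromo at this place. These are a 1.5-fold higher number from compound 1 to compound 3 (0.18 log units; within the scatter) and a 1.9-fold lower number from compound 2 to compound 3 (0.27 log units; within the scatter), and both lie within the scatter. Exchanging one halogen for another is therefore expected to produce no shift beyond the scatter in this assay, and the estimated change is a 1.0-fold higher number from compound 3 to compound 4 (0.01 log units; within the scatter). For compound 4 the estimated value is 16 uM, with an expected range from 8 uM to 31 uM.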

Compound 4, concentration for half-maximal effect: 1.85 uM
For compound 4 the middle estimate is 8.6-fold (0.94 log units) above the measured one; measured number outside the range, below it.
By their numbers in this assay, from the lowest: compound 4; then compounds 1, 3 and 2 (each within the scatter of the next, the first and the last beyond it).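

At this place, on an aromatic carbon para to a large group, the two halogens are not interchangeable in this assay: there is an 8.5-fold lower number from compound 3 to compound 4 (0.93 log units; beyond the scatter), so bromo's closeness to trifluoromethyl and propoxy says nothing about fluoro. Fluoro also stands apart from the two non-halogen groups, with a 5.6-fold lower number from compound 1 to compound 4 (0.75 log units; beyond the scatter) and a 16-fold lower number from compound 2 to compound 4 (1.20 log units; beyond the scatter), which makes compound 4 the most potent of the four, and the first compound here whose steps to all the others lie beyond the scatter. No available evidence accounts for this difference.

The compounds shown leave open whether chloro or an unsubstituted phenyl would read closer to fluoro or to bromo, and how methoxy or an amine would read at this place. They also leave open whether fluoro keeps this edge when the ethyl groups on the shared core are replaced by methyl.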